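Working notes: from compound 2 to compound 3

The source may hold more compounds than are shown below. What is called first, only, known or untested is meant among the compounds shown, and "the series" means these compounds.

Measured so far:
compound 1, `Clc1cccc(CSc2nnc(-c3ccncc3)n2-c2ccccc2)c1`: 10500 nM
compound 2, `O=C(CSc1nnc(-c2ccncc2)n1-c1ccccc1)N/N=C/c1ccc(O)cc1`: > 50000 nM

Both compounds were tested in a functional assay on MCF7 cells (Homo sapiens) for inhibition, read by MTT assay, with a stated time of 48 h; on this read-out higher numbers stand for weaker inhibition and lower numbers for stronger inhibition. Compound 1 gives 10500 nM. For compound 2 the read-out is only a limit, > 50000 nM, so compound 2 has no number on this scale but sits at the limit, as one of the two values does (the limit of > 50000 nM in this assay, at which 1 of the 2 values shown sits). The two measured compounds differ in more than one place, so no single step between measured compounds is shown, and the size of any one change in this series cannot be read from the numbers.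

Compound 3, `O=C(CSc1nnc(-c2ccncc2)n1-c1ccccc1)N/N=C/c1cccc(F)c1`, differs from compound 2 in one place: 3-fluorophenyl in place of 4-hydroxyphenyl on a carbon with a double bond to nitrogen. Since compound 2 stands at a limit, a step from it cannot be anchored. No step beyond the usual scatter is expected in either direction, and the expected step from compound 2 to compound 3 is an at least 1.1-fold lower number from compound 2 to compound 3 (0.04 log units; that floor lies within the scatter). Compound 3 is estimated at 45000 nM, in a range from 15000 nM to 120000 nM. A limit-only read-out for compound 3 is considered likely.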

Compound 3, half-maximal inhibitory concentration: > 50000 nM
Compound 3 was reported as a limit (the forecaster's own chance of this, stated with the estimate: 60%); middle value at least 1.1-fold (0.04 log units) away from the limit.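

No step can be read from compound 2 to compound 3, because the read-outs of both compounds are limits and not numbers: the limit of > 50000 nM in this assay, at which 2 of the 3 values shown sit.

The compounds shown leave open whether, and in which direction, 3-fluorophenyl in place of 4-hydroxyphenyl on a carbon with a double bond to nitrogen changes the read-out.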